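Methyl in Place of Fluoro on the Aryl Ring

The compounds below may be only part of what the source reports. "The series", "measured", "known", "first", "only" and "open" are said of these compounds alone.

In a functional assay on PC-3 cells (Homo sapiens) for antiproliferative activity, read by MTT assay, with a stated time of 72 h (on this read-out higher numbers stand for weaker inhibition and lower numbers for stronger inhibition), compound 2 `COc1cc(/C=C/C(=O)OCCSc2nc(-c3ccc(S(C)(=O)=O)cc3)n(-c3ccc(F)cc3)n2)ccc1OC(C)=O` gives 12800 nM. For the measured compounds named here, compound 1 `COc1cc(/C=C/C(=O)OCCSc2nc(-c3ccc(S(C)(=O)=O)cc3)n(-c3ccc(Br)cc3)n2)ccc1OC(C)=O` gives 13100 nM, and the two numbers lie within the scatter of each other, as the single measured step of a 1.0-fold lower number from compound 1 to compound 2 (0.01 log units; within the scatter) shows. Compound 3 `COc1cc(/C=C/C(=O)OCCSc2nc(-c3ccc(S(C)(=O)=O)cc3)n(-c3ccc(C)cc3)n2)ccc1OC(C)=O` differs from compound 2 by methyl in place of fluoro on an aromatic carbon. Going by the values given here, only that one measured step bears on this change, and it stayed within the scatter, so for compound 3 no step beyond the scatter is expected in this assay. Compound 3 is therefore estimated at 12000 nM (from 6000 nM to 25000 nM), an expected step of a 1.1-fold lower number from compound 2 to compound 3 (0.03 log units; within the scatter).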

Compound 3, half-maximal inhibitory concentration: 15500 nM
Estimate against measurement, compound 3: 1.3-fold (0.11 log units) below; the measured number falls inside the stated range.
By their numbers in this assay, from the lowest: compounds 2, 1 and 3 (each within the scatter of the next).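

With methyl on this aromatic carbon, a group other than a halogen now stands at the position, and in this assay the change still gives only a 1.2-fold higher number from compound 2 to compound 3 (0.08 log units; within the scatter) and a 1.2-fold higher number from compound 1 to compound 3 (0.07 log units; within the scatter). Fluoro, bromo and methyl, para to a large group, thus cannot be told apart by this read-out, though that holds for these three compounds alone. Nothing measured here offers an explanation for this flat result.

As far as these compounds go, whether an amine, a carboxylic acid or a longer chain at this position would move the number beyond the scatter remains open.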